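Ketone chain restored on a triazole bearing a dimethylaminophenyl

A few compounds are considered here, and "the series" means these few. Any claim that something is new, unique, unknown or untested is made for them only; others in the source may bear on it.

Compound 1 `COc1ccc(C(=O)CSc2nnc(-c3cc(OC)c(OC)c(OC)c3)n2-c2ccc(OC)cc2)cc1`: 18100 nM
Compound 2 `COc1cc(-c2nnc(SCc3ccccc3)n2-c2ccc(N(C)C)cc2)cc(OC)c1OC`: > 60000 nM

Of the compounds shown here, two sharing the trimethoxyphenyl-triazole core have been measured in a functional assay on HepG2 cells (Homo sapiens) for inhibition, read by MTT assay, with a stated time of 48 h; a lower number here means a stronger inhibitor, a higher number a weaker inhibitor. Compound 1 gives 18100 nM in this assay. For compound 2 the result is only a limit of the assay, > 60000 nM, so no number stands for it, and it sits at the limit of > 60000 nM in this assay, at which 1 of the 2 values shown sits. Going by the values given here, the two compounds differ in two places at once, so no single step between them can be read, and their values show only what they are.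

The piece follows compound 2 to compound 3 `COc1ccc(C(=O)CSc2nnc(-c3cc(OC)c(OC)c(OC)c3)n2-c2ccc(N(C)C)cc2)cc1`, whose change is (4-methoxyphenyl)carbonyl in place of phenyl on a saturated chain carbon bound to a sulfur. Compound 3 thereby carries the same sulfanyl chain as compound 1 and keeps the dimethylaminophenyl of compound 2. Since compound 2 gives only a limit, the size of the step to compound 3 cannot be fixed from it; a step toward stronger inhibition is expected, as an at least 2.4-fold lower number from compound 2 to compound 3 (0.38 log units; beyond the scatter). The estimate for compound 3 in this assay is 25000 nM, within the range 8000 nM to 70000 nM, guided by compound 1 at 18100 nM.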

Compound 3, half-maximal inhibitory concentration: 18800 nM
Compound 3: middle estimate off by 1.3-fold (0.12 log units), on the high side; low and high end bracket the measured number.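

In this assay, going by these compounds alone, (4-methoxyphenyl)carbonyl in place of phenyl on a saturated chain carbon bound to a sulfur gives an at least 3.1-fold lower number from compound 2 to compound 3 (0.50 log units; beyond the scatter), the first single change in this set that can be read, and it shows that this position on the sulfanyl chain matters for the read-out when the dimethylaminophenyl is kept. Compound 2 gives only a limit of the assay, so this step has a lower bound and no exact size: the limit of > 60000 nM in this assay, at which 1 of the 3 values shown sits. Dimethylamino in place of methoxy on an aromatic carbon gives a 1.0-fold higher number from compound 1 to compound 3 (0.02 log units; within the scatter), so with the ketone chain present, the two compounds cannot be told apart in this read-out.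

The entering group brings a carbonyl and a methoxy at once, so the compounds shown leave open which of the two goes with the step, a question that a plain phenylcarbonyl on the same chain carbon would address. They also leave open whether the dimethylamino and methoxy groups would still read alike with the benzylsulfanyl chain, and how a carboxylic acid, an amine or a longer chain would read at this position.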